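The source may hold more compounds than are shown below. What is called first, only, known or untested is meant among the compounds shown, and "the series" means these compounds.

Measured in an assay on isolated protein for inhibition of Indoleamine 2,3-dioxygenase 1 (Homo sapiens), read by fluorescence, with a stated time of 60 min; on this read-out higher numbers stand for weaker inhibition and lower numbers for stronger inhibition:
- compound 1, `CN(C)S(=O)(=O)CCNc1nonc1/C(=N/O)Nc1ccc(F)c(Br)c1`: compound 1 gives 105 nM
- compound 2, `O=S(=O)(CCNc1nonc1/C(=N/O)Nc1ccc(F)c(Br)c1)N1CCC1`: compound 2 gives 191 nM
- compound 3, `C#CCNS(=O)(=O)CCNc1nonc1/C(=N/O)Nc1ccc(F)c(Br)c1`: compound 3 gives 218 nM

Compound 3 carries the highest of the three numbers, but the separation from compound 2 is small: a 1.1-fold higher number from compound 2 to compound 3 (0.06 log units; within the scatter). Only compound 1 stands apart from it, a 2.1-fold higher number from compound 1 to compound 3 (0.32 log units; beyond the scatter). All three differ solely in the substituent on the sulfonamide nitrogen, and the three steps among them are modest at most; a 1.8-fold higher number from compound 1 to compound 2 (0.26 log units; within the scatter) as well.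

Compound 4 is `O=S(=O)(CCNc1nonc1/C(=N/O)Nc1ccc(F)c(Br)c1)NCC1CC1`. The change from compound 3 is cyclopropyl in place of ethynyl on a saturated chain carbon bound to a sulfonamide nitrogen, again a change confined to the sulfonamide nitrogen substituent. The measured steps bearing on this position, from compound 1 to compound 2, from compound 1 to compound 3 and from compound 2 to compound 3, were all small, so the step from compound 3 to compound 4 in this assay is expected to stay within the scatter, with no clear direction; the expected step is a 1.1-fold lower number from compound 3 to compound 4 (0.04 log units; within the scatter). Compound 4 is therefore estimated at 200 nM, with a range from 100 nM to 400 nM.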

Compound 4, half-maximal inhibitory concentration: 312 nM
Beside the measured number, compound 4's estimate is 1.6-fold (0.19 log units) below it, and the stated range covers the measured number.
By their numbers in this assay, from the lowest: compounds 1, 2, 3 and 4 (each within the scatter of the next, the first and the last beyond it).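

In this assay, cyclopropyl in place of ethynyl on a saturated chain carbon bound to a sulfonamide nitrogen gives only a 1.4-fold higher number from compound 3 to compound 4 (0.16 log units; within the scatter), and (cyclopropylmethyl)amino in place of azetidin-1-yl on a sulfonyl sulfur gives a 1.6-fold higher number from compound 2 to compound 4 (0.21 log units; within the scatter), so neither step separates these groups. The largest step at this position now reads a 3.0-fold higher number from compound 1 to compound 4 (0.47 log units; beyond the scatter), which makes (cyclopropylmethyl)amino the second group, after propargylamino, to stand beyond the scatter from dimethylamino, while azetidin-1-yl in compound 2 goes against any general trend by staying within it. No measurement here accounts for these steps.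

Open, as far as these compounds go, is how a carboxylic acid, a primary amine or a longer alkyl chain on the sulfonamide nitrogen would read in this assay. Also open, from the compounds shown here alone, is whether any such group would give a number clearly apart from that of compound 1.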